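Cyclopropyl on the Hydroxypiperidine Ring of Compound 2

A few compounds are considered here, and "the series" means these few. Any claim that something is new, unique, unknown or untested is made for them only; others in the source may bear on it.

Measured compounds:
Compound 1 `Cc1nc(N(C)C2CCCC2)nc2ccc(NC(=O)/C=C/c3ccc(Cl)cc3)cc12` gives 57 nM in a functional assay on CHO-K1 cells for antagonist activity at melanin-concentrating hormone receptor 1 (Homo sapiens), read by inositol phosphate accumulation, with stated times of 10 min and 45 min; a lower number here means a stronger inhibitor, a higher number a weaker inhibitor.
Compound 2 `C/C(=C\C(=O)Nc1ccc2nc(N3CCC(O)CC3)nc(C)c2c1)c1ccc(Cl)cc1` gives 227 nM in this assay.

Of the two measured compounds, compound 2 has the higher number in this assay; compound 1 has the lower number, and the gap between them lies beyond the usual scatter. Compound 3 `C/C(=C\C(=O)Nc1ccc2nc(N3CCC(O)(C4CC4)CC3)nc(C)c2c1)c1ccc(Cl)cc1` is not yet measured. Its change from compound 2 is cyclopropyl in place of hydrogen on a saturated ring carbon, so the hydroxyl on that carbon is kept and a small carbocycle is added alongside it.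

Among the compounds with values here, no step between measured compounds speaks to this change, and the two measured compounds differ in more than one place, so their values do not isolate it. The step from compound 2 to compound 3 in this assay is therefore expected to be small, a 1.5-fold lower number from compound 2 to compound 3 (0.18 log units; within the scatter), possibly not beyond the scatter. Compound 3 is estimated at 150 nM, with a range from 50 nM to 500 nM.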

Compound 3, half-maximal inhibitory concentration: 340 nM
For compound 3 the middle estimate is 2.3-fold (0.36 log units) below the measured one; measured number inside the range.
By their numbers in this assay, from the lowest: compound 1; then compounds 2 and 3 (each within the scatter of the next).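

In this assay, the change from 4-hydroxypiperidin-1-yl to 4-cyclopropyl-4-hydroxypiperidin-1-yl gives a 1.5-fold higher number from compound 2 to compound 3 (0.18 log units; within the scatter), so compounds 2 and 3 cannot be told apart. Within the data shown here, this is the first direct reading at this saturated ring carbon, and it shows that adding cyclopropyl while keeping the hydroxyl leaves the number within the scatter. Nothing available explains this outcome at the level of the structure.

The compounds shown leave open whether a methyl group or a longer chain on the same carbon would also stay within the scatter. They also leave open what an amine or a carboxylic acid in place of the hydroxyl would do, and whether any group on this carbon could bring the number down to a step beyond the scatter.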